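The compounds below may be only part of what the source reports. "The series", "measured", "known", "first", "only" and "open" are said of these compounds alone.

Three compounds have been measured so far:
compound 1 `COc1cccc(/C=C2\CCC/C(=C\c3ccc(O)cc3)C2=O)c1OC`
compound 2 `COc1cc(/C=C2\CCC/C(=C\c3cccc(OC)c3OC)C2=O)cc(OC)c1`
compound 3 `COc1ccc(/C=C2\CCC/C(=C\c3ccccc3Cl)C2=O)cc1OC`

In a functional assay on HT-1080 cells (Homo sapiens) for cytotoxicity, read by MTT assay, with a stated time of 72 h (a higher number here means a weaker inhibitor, a lower number a stronger inhibitor), compound 2 gives 4500 nM and compound 3 gives 6800 nM; these two numbers lie within the scatter of each other, so neither compound can be set apart from the other. In this assay compound 1 gives > 20000 nM, which is a limit of the assay rather than a number: the limit of > 20000 nM in this assay, at which 1 of the 3 values shown sits. Compound 3 thus stands beside compound 2 among the values that were actually read as numbers. Compound 4 `COc1ccc(/C=C2\CCC/C(=C\c3cccc(Cl)c3Cl)C2=O)cc1OC` differs from compound 3 by chloro in place of hydrogen on an aromatic carbon. Within the data shown here, no measured pair shows the effect of such a change, so the step from compound 3 to compound 4 is expected to be small, in no fixed direction, and not beyond the scatter: a 1.2-fold lower number from compound 3 to compound 4 (0.09 log units; within the scatter). Compound 4 is therefore estimated at 5500 nM, with a range from 1800 nM to 20000 nM.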

Compound 4, half-maximal inhibitory concentration: 8800 nM
Beside the measured number, compound 4's estimate is 1.6-fold (0.20 log units) below it; measured number inside the range.
By their numbers in this assay, from the lowest: compounds 2, 3 and 4 (each within the scatter of the next). At a limit, above all of these: compound 1.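

This is the first pair shown that differs in only one place. In this assay, going from 2-chlorophenyl to 2,3-dichlorophenyl gives a 1.3-fold higher number from compound 3 to compound 4 (0.11 log units; within the scatter), so a chloro at this aromatic carbon, ortho to a chloro group, leaves the two compounds impossible to tell apart. Nothing measured here bears on why the two read alike. On these data alone, it remains open whether an amine or a carboxylic acid on this same carbon would move the number beyond the scatter. As far as these compounds go, whether chloro here would act alike with other groups on the opposite aromatic ring is also open.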